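A few compounds are considered here, and "the series" means these few. Any claim that something is new, unique, unknown or untested is made for them only; others in the source may bear on it.

In a functional assay on MCF7 cells (Homo sapiens) for cytotoxicity, read by MTT assay, with a stated time of 72 h (a higher number here means a weaker inhibitor, a lower number a stronger inhibitor), compound 1 `CNC(=O)c1cc(Oc2ccc(NC(=O)c3nccc(-c4ccccc4)n3)cc2)ccn1` gives 39100 nM. Compound 2 `CNC(=O)c1cc(Oc2ccc(NC(=O)c3nccc(-c4ccc(OC)cc4)n3)cc2F)ccn1` has no number in this read-out, and its entry of > 100000 nM is a limit. Compound 3 `CNC(=O)c1cc(Oc2ccc(NC(=O)c3nccc(-c4ccc(OC)cc4)n3)cc2)ccn1` has not yet been measured. It differs from compound 2 in one place: hydrogen in place of fluoro on an aromatic carbon, with hydrogen in place of fluoro on an aromatic carbon, ortho to a (2-(methylcarbamoyl)pyridin-4-yl)oxy group. For the measured compounds named here, no measured pair isolates this change, and the limit on compound 2 leaves the starting point open. A modest move toward stronger inhibition in this assay is therefore expected, though a result close to that of compound 2 would be no surprise. Going by the values given here, the only numerical guide is compound 1 at 39100 nM, which also carries hydrogen at this place but differs from compound 3 elsewhere, so it gives only a rough level. The expected size of the change is an at least 1.8-fold lower number from compound 2 to compound 3 (0.25 log units; that floor lies within the scatter). For compound 3 the estimated value is 55000 nM, with an expected range of 20000 nM to 100000 nM.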

Compound 3, half-maximal inhibitory concentration: 35200 nM
For compound 3 the middle estimate is 1.6-fold (0.19 log units) above the measured one, and the stated range covers the measured number.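

In this assay, the change of fluoro to hydrogen on the aromatic carbon ortho to a (2-(methylcarbamoyl)pyridin-4-yl)oxy group now has a measured consequence, an at least 2.8-fold lower number from compound 2 to compound 3 (0.45 log units; beyond the scatter), and this step lies beyond the usual scatter. That step is only a floor, because compound 2 carries a limit and not a number: the limit of > 100000 nM in this assay, at which 1 of the 3 values shown sits. With hydrogen at this position, methoxy in place of hydrogen on an aromatic carbon gives a 1.1-fold lower number from compound 1 to compound 3 (0.05 log units; within the scatter), which lies within the scatter, so among these compounds the methoxy group alone does not separate compound 3 from compound 1, and the fluoro is the one change that goes with the limit entry of compound 2.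

The compounds shown leave open how far the true number of compound 2 lies past its limit, and whether fluoro at this position would give a similar step on the core of compound 1, which has hydrogen in place of the methoxy group. They also leave open what chloro, a methyl group or an amine at this position would give in this assay.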